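Hydroxyethyl in Place of Benzyl on the Dithioester

The compounds below may be only part of what the source reports. "The series", "measured", "known", "first", "only" and "open" are said of these compounds alone.

Measured so far:
compound 1, `CC1(C)CC(=O)C=C(Nc2ccc(Cl)cc2Cl)C1`: 17.6 ug/mL
compound 2, `CC1(C)CC(=O)C(C(=S)SCc2ccccc2)=C(Nc2ccc(Cl)cc2Cl)C1`: > 50 ug/mL

In a functional assay on PBMC cells (Homo sapiens) for inhibition, read by thymidine incorporation, with a stated time of 72 h (on this read-out higher numbers stand for weaker inhibition and lower numbers for stronger inhibition), compound 1 gives 17.6 ug/mL. For compound 2 the result is only a limit, > 50 ug/mL, so compound 2 stands at the limit of > 50 ug/mL in this assay, at which 1 of the 2 values shown sits, and no number is known for it. Compound 3, `CC1(C)CC(=O)C(C(=S)SCCO)=C(Nc2ccc(Cl)cc2Cl)C1`, has not been measured; it differs from compound 2 by hydroxymethyl in place of phenyl on a saturated chain carbon bound to a sulfur. Going by the values given here, with no measured step between the two known compounds, the change expected an at least 1.1-fold lower number from compound 2 to compound 3 (0.04 log units; that floor lies within the scatter) is small, within the scatter, with a fair chance of another limit. Compound 3 is estimated at 45 ug/mL, with a range from 15 ug/mL to 150 ug/mL.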

Compound 3, half-maximal inhibitory concentration: > 50 ug/mL
Compound 3 was reported as a limit; the forecaster's own chance of this, stated with the estimate: 50%; middle value at least 1.1-fold (0.04 log units) from the limit.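

In this assay, replacing benzyl with 2-hydroxyethyl leaves the result a limit, so the step between compound 2 and compound 3 cannot be read, and both compounds share one reading: the limit of > 50 ug/mL in this assay, at which 2 of the 3 values shown sit.

Placing this ringless group instead of a hydrogen atom on the double-bonded ring carbon gives an at least 2.8-fold higher number from compound 1 to compound 3 (0.45 log units; beyond the scatter). The weaker inhibition therefore does not require the phenyl ring of benzyl.

On these data alone, how far compound 2 and compound 3 actually differ stays open. So does whether an amine or a carboxylic acid on the sulfur chain would return a measurable number.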